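Quinoline carboxamides: hydroxy to carboxy on the core

The compounds below may be only part of what the source reports. "The series", "measured", "known", "first", "only" and "open" are said of these compounds alone.

Measured compounds:
- compound 1, `Cc1c(C(=O)Nc2c(F)cc(-c3cccc(F)c3)cc2F)nc2ccc(C(F)(F)F)cc2c1O`: 9.38%
- compound 2, `COc1ccc2nc(C(=O)Nc3ccc(-c4ccccc4)cc3)c(C)c(O)c2c1`: 7.58%
- compound 3, `Cc1c(C(=O)Nc2c(F)cc(-c3cccc(F)c3)cc2F)nc2ccc(C(F)(F)F)cc2c1C(=O)O`: 6.42%

All three were tested in a functional assay on Hep 3B2 cells (Homo sapiens) for antiproliferative activity, read by MTT assay, with a stated time of 24 h, tested at 0.41 ug/mL; on this read-out lower numbers stand for a weaker effect and higher numbers for a stronger effect at the one concentration tested. Compound 1 gives 9.38%, compound 2 gives 7.58% and compound 3 gives 6.42%; the three numbers lie within the usual scatter of one another, so no order among them can be read.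

Compound 1 and compound 3 differ in one place: carboxy in place of hydroxy on an aromatic carbon. The step that goes with it is a number 3 percentage points lower from compound 1 to compound 3 (within the scatter). Compound 2 and compound 1 differ in more than one place; the difference between the two cores is not broken down here.

Compound 4, `COc1ccc2nc(C(=O)Nc3ccc(-c4ccccc4)cc3)c(C)c(C(=O)O)c2c1`, is not yet measured. It stands to compound 2 as compound 3 stands to compound 1: carboxy in place of hydroxy on an aromatic carbon. The place line reads the same word for word in both pairs, so this is the same change made on a second core.

In this assay, among the measured compounds shown here, the step from compound 2 to compound 4 is expected to be of about the size seen from compound 1 to compound 3, that is a number 2.1 percentage points lower from compound 2 to compound 4 (within the scatter), because the single earlier instance gave a number 3 percentage points lower from compound 1 to compound 3 (within the scatter) and that step lay within the scatter. On this basis compound 4 is estimated at 5.5%, with a range from -4% to 15%.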

Compound 4, a percentage reported as inhibition, at one concentration (the size of the read-out at that concentration, not a potency): 5.31%
For compound 4 the middle estimate is 0.2 percentage points above the measured one; the measured number falls inside the stated range.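

In this assay, carboxy in place of hydroxy on an aromatic carbon gives, on the second core, a number 2.3 percentage points lower from compound 2 to compound 4 (within the scatter), and the two instances of the change compare as follows: the same change on two cores in this assay, a number 3 percentage points lower (within the scatter) from compound 1 to compound 3 and a number 2.3 percentage points lower (within the scatter) from compound 2 to compound 4, 0.7 percentage points apart, within the scatter of two such steps Within these two pairs, the change therefore carries from one core to the other with no difference in step size that can be read, even though the cores differ in more than one place. Among the compounds shown here, this does not show that the change has any real effect on either core: both steps lie within the scatter, so neither can be told apart from no step at all, and two pairs at one concentration give no rule for other cores.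

The compounds shown leave open what a group other than hydroxy or carboxy, such as an amine or a nitrile, would do at this place, opposite the ring nitrogen and ortho to a methyl group. They also leave open whether the step would stay the same on a core carrying a chloro group in place of the trifluoromethyl or methoxy group, or with the methyl group replaced by a longer chain.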